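The source may report more compounds than this note shows. Statements on the series, on what has been measured and on what is new or still open speak of the compounds shown alone.

Compound 1 `COC(=O)[C@@]1(C)CCC=C2[C@@H]1CC[C@@H](C)[C@]2(C)Cc1c[nH]c2c(Br)cccc12` and compound 2 `COC(=O)[C@@]1(C)CCC=C2[C@@H]1CC[C@@H](C)[C@]2(C)Cc1c[nH]c2c(Cl)cccc12` share one core and differ in a single place: chloro in place of bromo on an aromatic carbon. In a functional assay on WiDr cells (Homo sapiens) for inhibition, read by sulforhodamine B assay, with a stated time of 48 h (a higher number here means a weaker inhibitor of growth, a lower number a stronger inhibitor of growth), compound 1 gives 32000 nM, and compound 2 gives 31000 nM, so this change made a 1.0-fold lower number from compound 1 to compound 2 (0.01 log units; within the scatter). Compound 3 `COC(=O)[C@@]1(C)CC[C@@H]2C3=C1CC[C@@H](C)[C@]3(C)C[C@@H]1c3cccc(Br)c3N[C@H]21` is built from the same atoms as compound 1, joined differently; the difference between the two cores is not broken down here. In this assay compound 3 gives 54000 nM, a value within the scatter of those of compound 1 and compound 2. Compound 4 `COC(=O)[C@@]1(C)CC[C@@H]2C3=C1CC[C@@H](C)[C@]3(C)C[C@@H]1c3cccc(Cl)c3N[C@H]21` stands to compound 3 as compound 2 stands to compound 1: chloro in place of bromo on an aromatic carbon. This is the same kind of change as before, though here the aromatic carbon belongs to a fused or bridged system of five rings, where in compound 1 it belongs to a system of two rings. Because the earlier step was a 1.0-fold lower number from compound 1 to compound 2 (0.01 log units; within the scatter), the estimated step here is no change at the digits printed from compound 3 to compound 4 (within the scatter). Compound 4 is therefore expected to give 54000 nM, with a likely range from 25000 nM to 110000 nM.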

Compound 4, concentration for 50% growth inhibition: 67000 nM
Beside the measured number, compound 4's estimate is 1.2-fold (0.09 log units) below it; the range from low to high includes it.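

In this assay the exchange of bromo for chloro on the aromatic carbon gives a 1.2-fold higher number from compound 3 to compound 4 (0.09 log units; within the scatter) on the core of compound 3. Set beside the same exchange on the core of compound 1, the two steps compare as follows: the same change on two cores in this assay, a 1.0-fold lower number (0.01 log units; within the scatter) from compound 1 to compound 2 and a 1.2-fold higher number (0.09 log units; within the scatter) from compound 3 to compound 4, 1.3-fold (0.11 log units) apart, within the scatter of two such steps. So in this series the exchange carried from one core to the other with no measurable difference, and bromo and chloro could not be told apart on either core; this does not show that the same would hold on a third core, in another assay, or for a group other than these two halogens.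

The compounds shown leave open whether a fluoro, a methoxy or a plain hydrogen on that aromatic carbon would behave alike on both cores. They also leave open whether a carboxylic acid or an amide in place of the methyl ester would move the numbers at all.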